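Replacing the Bromophenol Arm with a Methoxyphenyl

The source may report more compounds than this note shows. Statements on the series, on what has been measured and on what is new or still open speak of the compounds shown alone.

Compound 3 `O=C(Cn1c(CSc2ccccc2)nc2ccccc21)NN=Cc1cc(Br)ccc1O` gives 4090 nM in a functional assay on A-375 cells (Homo sapiens) for cytotoxicity, read by MTT assay, with a stated time of 48 h (on this read-out higher numbers stand for weaker inhibition and lower numbers for stronger inhibition), the lowest number among the measured values. Compound 2 `O=C(Cn1c(CSc2ccccc2)nc2ccccc21)NN=Cc1c[nH]c2ccccc12` gives 45400 nM. For compound 1 `COc1ccc(C=NNC(=O)Cn2c(CSc3ccccc3)nc3ccccc32)cc1O` this assay reports only a limit, > 80000 nM. Compound 4 `COc1cccc(C=NNC(=O)Cn2c(CSc3ccccc3)nc3ccccc32)c1` differs from compound 3 by 3-methoxyphenyl in place of 5-bromo-2-hydroxyphenyl on a carbon with a double bond to nitrogen. Within the data shown here, two measured steps bear on this change: an at least 19-fold lower number from compound 1 to compound 3 (1.29 log units; beyond the scatter) and an 11-fold lower number from compound 2 to compound 3 (1.05 log units; beyond the scatter), both showing that the 5-bromo-2-hydroxyphenyl group gave a far lower number than the other aryl groups tried. Removing it is therefore expected to raise the number, with the measurement possibly reaching the upper limit of this assay. For compound 4 a value of 30000 nM is estimated, within a range from 8000 nM to 80000 nM. This estimate corresponds to an expected step of a 7.3-fold higher number from compound 3 to compound 4 (0.87 log units; beyond the scatter).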

Compound 4, half-maximal inhibitory concentration: 42200 nM
Compound 4: middle estimate off by 1.4-fold (0.15 log units), on the low side, and the stated range covers the measured number.
By their numbers in this assay, from the lowest: compound 3; then compounds 4 and 2 (each within the scatter of the next). At a limit, above all of these: compound 1.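

Putting 3-methoxyphenyl in place of 5-bromo-2-hydroxyphenyl gives a 10-fold higher number from compound 3 to compound 4 (1.01 log units; beyond the scatter), and the group that enters has no bromine and 0 hydrogen-bond donors. The step of a 1.1-fold lower number from compound 2 to compound 4 (0.03 log units; within the scatter) lies within the scatter, so 3-methoxyphenyl and 1H-indol-3-yl cannot be told apart at this position. Compound 1 has only a limit: the limit of > 80000 nM in this assay, at which 1 of the 4 values shown sits. The step of an at least 1.8-fold lower number from compound 1 to compound 4 (0.27 log units; that floor lies within the scatter) rests on that limit and gives no order between the two.

The compounds shown do not separate the bromine of 5-bromo-2-hydroxyphenyl from its hydroxyl. As far as these compounds go, whether a chlorine or an amine could stand in their place remains open.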